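The compounds below may be only part of what the source reports. "The series", "measured", "known", "first", "only" and "open" are said of these compounds alone.

Of the compounds shown here, three have been measured in a functional assay on A-431 cells (Homo sapiens) for cytotoxicity, read by MTT assay, with a stated time of 48 h; on this read-out higher numbers stand for weaker inhibition and lower numbers for stronger inhibition. Compound 1 `CCCCCCCCNC(=O)[C@@H](NC(=O)c1ccco1)[C@@H](C)O` gives 64500 nM in this assay. Compound 2 `CCCCCCCCNC(=O)[C@@H](NC(=O)c1nccc2ccccc12)[C@@H](C)O` gives 26900 nM in this assay, the second highest of the three numbers. Its nearest neighbour is compound 3 `CCCCCCCCCCCCNC(=O)[C@@H](NC(=O)c1cccs1)[C@@H](C)O`, which gives 16600 nM in this assay, a gap that lies within the usual scatter, while the gap between compound 2 and compound 1 lies beyond it. Compound 4 `CCCCCCCCCCCCCCNC(=O)[C@@H](NC(=O)c1nccc2ccccc12)[C@@H](C)O` has not yet been measured. It differs from compound 2 in one place: hexyl in place of hydrogen on a saturated chain carbon, eight bonds along the chain from an amide-type nitrogen. Among the compounds with values here, no pair of measured compounds differs in only this way, so no measured step shows how a longer chain behaves in this assay. Compound 3 carries a longer chain than compound 1 and gives a lower number, but its ring also differs, so that pair shows only what its two values show. In this assay the expected step is a modest move toward a lower number, a 1.8-fold lower number from compound 2 to compound 4 (0.25 log units; within the scatter), possibly no larger than the scatter. Compound 4 is therefore estimated at 15000 nM, with a range from 5000 nM to 50000 nM.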

Compound 4, half-maximal inhibitory concentration: 23000 nM
Compound 4: the middle estimate sits 1.5-fold (0.19 log units) below what was measured; measured number inside the range.
By their numbers in this assay, from the lowest: compounds 3, 4 and 2 (each within the scatter of the next); then compound 1.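

In this assay, within the data shown here, this pair gives the first direct reading of a change in chain length with the rest of the molecule held constant: hexyl in place of hydrogen on a saturated chain carbon, eight bonds along the chain from an amide-type nitrogen, gives a 1.2-fold lower number from compound 2 to compound 4 (0.07 log units; within the scatter). On this core, then, the added hexyl produces no change that can be told apart from the usual scatter of repeated measurements, so the chain can be extended this far without a clear effect on the read-out. Nothing measured here bears on why this is so.

Still open, going by these compounds, is whether a chain ending in an amine or a carboxylic acid at this position would shift the number beyond the scatter. Also open, on these data alone, is whether the same added hexyl would behave alike on the cores of compound 1 and compound 3.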